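Chain extension at the aminomethyl group of compound 1

A few compounds are considered here, and "the series" means these few. Any claim that something is new, unique, unknown or untested is made for them only; others in the source may bear on it.

Compound 1 `CCCCCCCCCCc1ccc(-c2noc(CN)n2)cc1` gives 62% in an assay on HeLa cells for inhibition of sphingosine-1-phosphate transporter SPNS2 (Mus musculus), read by LC-MS, tested at 2 uM (on this read-out lower numbers stand for less inhibition and higher numbers for more inhibition at the one concentration tested (going by the name of the read-out)), the second highest of the three numbers; compound 3 `CCCCCCCCCCc1ccc(-c2noc(C3CCNCC3)n2)cc1` gives 66% and compound 2 `CCCCCCCCCCc1ccc(-c2noc(C3CCNC3)n2)cc1` gives 26%. The step of a number 4 percentage points higher from compound 1 to compound 3 (within the scatter) lies within the scatter, whereas a number 36 percentage points lower from compound 1 to compound 2 (beyond the scatter) and a number 40 percentage points higher from compound 2 to compound 3 (beyond the scatter) are large. Compound 4 `CCCCCCCCCCc1ccc(-c2noc([C@H](N)CCCCN)n2)cc1` carries 4-aminobutyl in place of hydrogen on a saturated chain carbon bound to an amine nitrogen and an aromatic carbon. Going by the values given here, none of the measured steps concerns this change: all three exchange the aminomethyl group for a ring, while compound 4 keeps its amine and extends the chain. With nothing bearing on it, no step beyond the scatter is expected from compound 1 to compound 4, and the estimate is no change at the digits printed from compound 1 to compound 4 (within the scatter). Compound 4 is thus expected at about 62%, within 40% to 80%.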

Compound 4, a percentage reported as inhibition, at one concentration (the size of the read-out at that concentration, not a potency): 50%
Estimate against measurement, compound 4: 12 percentage points above; the measured number falls inside the stated range.
By their numbers in this assay, from the lowest: compound 2; then compound 4; then compounds 1 and 3 (each within the scatter of the next).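

Putting 4-aminobutyl on the saturated chain carbon gives a number 12 percentage points lower from compound 1 to compound 4 (beyond the scatter), so this carbon accepts a chain that retains the amine of compound 1 at a modest cost. The resulting 1,5-diaminopentyl group ranks below piperidin-4-yl, a number 16 percentage points lower from compound 3 to compound 4 (beyond the scatter), and above pyrrolidin-3-yl, a number 24 percentage points higher from compound 2 to compound 4 (beyond the scatter). Nothing available accounts for these differences.

On these data alone, it remains open whether the terminal amine matters, as a plain butyl chain at this carbon would show. As far as these compounds go, the effect of the opposite configuration at this carbon also remains open.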